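Replacing the bromohexyl chain with acetyl on the shared core

The source may report more compounds than this note shows. Statements on the series, on what has been measured and on what is new or still open speak of the compounds shown alone.

In a functional assay on U-937 cells (Homo sapiens) for cytotoxicity, read by MTT assay, with a stated time of 24 h (a higher number here means a weaker inhibitor, a lower number a stronger inhibitor), compound 3 `BrCCCCCCOc1c(Br)cc(Br)cc1Oc1ccc(Br)cc1Br` gives 33.8 ug/mL, level within the scatter with compound 1 `BrCCCCOc1c(Br)cc(Br)cc1Oc1ccc(Br)cc1Br` at 29 ug/mL and compound 2 `OCCCOc1c(Br)cc(Br)cc1Oc1ccc(Br)cc1Br` at 32.3 ug/mL. Compound 4 `CC(=O)Oc1c(Br)cc(Br)cc1Oc1ccc(Br)cc1Br` carries acetyl in place of 6-bromohexyl on an oxygen on an aromatic ring. The closest evidence comes from changes to that same chain: a 1.1-fold higher number from compound 1 to compound 2 (0.05 log units; within the scatter), a 1.2-fold higher number from compound 1 to compound 3 (0.07 log units; within the scatter) and a 1.0-fold higher number from compound 2 to compound 3 (0.02 log units; within the scatter), each within the scatter. None of these compounds carries acetyl, so no measured step matches this change directly. No step beyond the scatter is therefore expected, and no direction can be favoured. The expected result is a 1.1-fold lower number from compound 3 to compound 4 (0.05 log units; within the scatter). Compound 4 is estimated at 30 ug/mL, with an expected range of 14 ug/mL to 60 ug/mL.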

Compound 4, half-maximal inhibitory concentration: 32.3 ug/mL
Compound 4: middle estimate off by 1.1-fold (0.03 log units), on the low side; the measured number falls inside the stated range.
By their numbers in this assay, from the lowest: compounds 1, 2, 4 and 3 (each within the scatter of the next).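

In this assay, the position on an oxygen on an aromatic ring accepts acetyl as well as the alkyl chains: a 1.0-fold lower number from compound 3 to compound 4 (0.02 log units; within the scatter), no change at the digits printed from compound 2 to compound 4 (within the scatter) and a 1.1-fold higher number from compound 1 to compound 4 (0.05 log units; within the scatter). The earlier compounds shown here varied only saturated chains, whereas compound 4 shows that a short carbonyl-bearing group also stays within the scatter of all three. Nothing measured here explains this flat response.

Going by these compounds, it remains open whether an amine, a carboxylic acid or a chain longer than 6-bromohexyl at this oxygen would produce a step beyond the scatter. On these data alone, the effect of replacing the bromines on the shared core also remains open.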